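Swapping phenyl for ethoxycarbonyl in compound 2

The source may report more compounds than this note shows. Statements on the series, on what has been measured and on what is new or still open speak of the compounds shown alone.

Measured in a functional assay on B16 cells (Mus musculus) for cytotoxicity, read by MTT assay, with a stated time of 48 h; a higher number here means a weaker inhibitor, a lower number a stronger inhibitor:
Compound 1 `CCOC(=O)Cn1cc(CNC(=O)c2cn(CCOC(C)=O)nn2)nn1`: > 100000 nM, a limit of the assay
Compound 2 `CCOC(=O)Cn1cc(-c2cccc(NC(=O)c3cn(Cc4ccccc4)nn3)c2)nn1`: 21000 nM
Compound 3 `CC(=O)OCCn1cc(-c2cccc(NC(=O)c3cn(Cc4ccccc4)nn3)c2)nn1`: 25100 nM

Only compound 2 and compound 3 have actual numbers in this assay, and they do not separate, with a 1.2-fold higher number from compound 2 to compound 3 (0.08 log units; within the scatter). Compound 4 `CCOC(=O)Cn1cc(C(=O)Nc2cccc(-c3cn(CC(=O)OCC)nn3)c2)nn1` has not yet been measured. It differs from compound 2 by ethoxycarbonyl in place of phenyl on a saturated chain carbon bound to an aromatic nitrogen.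

Within the data shown here, no measured step makes this change. Among the measured compounds shown here, the one measured step, a 1.2-fold higher number from compound 2 to compound 3 (0.08 log units; within the scatter), swaps ethoxycarbonyl for acetoxymethyl and offers only weak guidance. Compound 1 has no phenyl and sits at the limit of > 100000 nM in this assay, at which 1 of the 3 values shown sits, which is a limit and not a number. A move towards a higher number is therefore expected, though compound 1 differs from compound 2 in more than one place. The expected change is an estimated 2.1-fold higher number from compound 2 to compound 4 (0.33 log units; beyond the scatter). For compound 4 the estimate is 45000 nM, with an expected range from 18000 nM to 100000 nM.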

Compound 4, half-maximal inhibitory concentration: > 100000 nM
Compound 4: no number, only a limit; the forecaster's own chance of this, stated with the estimate: 20%; middle value at least 2.2-fold (0.34 log units) away from the limit.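

In this assay, compound 4 gives > 100000 nM, a limit of the assay and not a number, and it shares that limit with one other compound: the limit of > 100000 nM in this assay, at which 2 of the 4 values shown sit.

The earlier step, a 1.2-fold higher number from compound 2 to compound 3 (0.08 log units; within the scatter), changed a different group and did not separate its two compounds, whereas ethoxycarbonyl in place of phenyl on a saturated chain carbon bound to an aromatic nitrogen gives an at least 4.7-fold higher number from compound 2 to compound 4 (0.67 log units; beyond the scatter), so this is the first single change shown to move the result beyond the scatter. On these data alone, since one end of that step is a limit, its true size remains unknown.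

The compounds shown leave open whether the shift reflects the loss of phenyl or the arrival of ethoxycarbonyl. A cyclohexyl group or a carboxylic acid in this place could help to tell the two apart.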